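Compound 3 to compound 4: ethyl shortened to methyl

The compounds below may be only part of what the source reports. "The series", "measured", "known", "first", "only" and "open" are said of these compounds alone.

Compound 1, `C=C(C)C(=O)c1ccc(OCc2nc(-c3ccccc3)cs2)cc1Cl`: 100%
Compound 2, `C=C(CC)C(=O)c1ccc(OCc2nc(-c3ccc4ccccc4c3)cs2)c(C)c1C`: 0%
Compound 3, `C=C(CC)C(=O)c1ccc(OCc2nc(-c3ccc(C(F)(F)F)cc3)cs2)c(C)c1C`: 0%

In an assay on HL-60 cells for inhibition of glutathione S-transferase P (Homo sapiens), read by spectrophotometry, tested at 5 uM (on this read-out higher numbers stand for more inhibition at the one concentration tested (going by the name of the read-out) and lower numbers for less inhibition), compound 3 gives 0%. It is level with compound 2 at the digits shown, the two together forming the low end of the three numbers, while compound 1 lies far above both, beyond the scatter. Compound 4, `C=C(C)C(=O)c1ccc(OCc2nc(-c3ccc(C(F)(F)F)cc3)cs2)c(C)c1C`, differs from compound 3 in one place: hydrogen in place of methyl on a saturated chain carbon bound to a double-bonded chain carbon. Among the measured compounds shown here, the only measured step, no change at the digits printed from compound 2 to compound 3 (within the scatter), concerns the aryl group and not this change, so no measured step bears on it directly. Compound 1 carries the methyl but differs in other places too, so its value cannot be assigned to this change. Compound 4 is therefore expected to show no step beyond the scatter, a number 8 percentage points higher from compound 3 to compound 4 (within the scatter). The estimated value of compound 4 is 8%, within 0% to 40%.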

Compound 4, a percentage reported as inhibition, at one concentration (the size of the read-out at that concentration, not a potency): 3.6%
The estimate for compound 4 lay 4.4 percentage points above the measured number; low and high end bracket the measured number.
By their numbers in this assay, from the lowest: compounds 2, 3 and 4 (each within the scatter of the next); then compound 1.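

In this assay, the change of ethyl to methyl, hydrogen in place of methyl on a saturated chain carbon bound to a double-bonded chain carbon, gives a number 3.6 percentage points higher from compound 3 to compound 4 (within the scatter), the first step read at this position. With the rest of compound 3 held fixed, ethyl and methyl therefore cannot be told apart here. No available evidence bears on this result.

As far as these compounds go, whether a longer chain such as propyl, or an amine, at this place would move the number stays open. So does what separates compound 1 from the others, since it differs from each in more than one place.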